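Chloro in Place of Methoxy: Expecting Compound 4

The source may hold more compounds than are shown below. What is called first, only, known or untested is meant among the compounds shown, and "the series" means these compounds.

Measured compounds in a functional assay on A549 cells (Homo sapiens) for inhibition, read by CCK-8 assay, with a stated time of 72 h, tested at 2 uM; on this read-out higher numbers stand for more inhibition of growth at the one concentration tested and lower numbers for less inhibition of growth:
- compound 1 `COc1ccc(SCc2ccc(/C=C/C(=O)Nc3ccccc3N)cc2)cc1OC` gives 65.5%
- compound 2 `Cc1cc(C)cc(SCc2ccc(/C=C/C(=O)Nc3ccccc3N)cc2)c1` gives 46.1%
- compound 3 `COc1ccc(SCc2ccc(C(=O)Nc3ccccc3N)cc2)cc1` gives 45.7%

Compound 3 stands lowest of the three numbers in this assay. Its nearest neighbour is compound 2, and the two lie within the usual scatter of each other, so they cannot be told apart. Compound 1 sits clearly higher than compound 3, beyond the scatter.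

Compound 4 `Nc1ccccc1NC(=O)c1ccc(CSc2ccc(Cl)cc2)cc1` differs from compound 3 in one place: chloro in place of methoxy on an aromatic carbon. Within the data shown here, no measured pair shows this same exchange. Among the measured compounds shown here, the only measured step, a number 19.4 percentage points lower from compound 1 to compound 2 (beyond the scatter), changes groups on a different ring and in a different pair of compounds, so it offers only a loose hint that altering substituents on that outer ring can move the number by a modest amount. With nothing directly comparable, compound 4 is expected to remain close to compound 3, and the estimated step of a number 0.3 percentage points higher from compound 3 to compound 4 (within the scatter) lies within the scatter. Compound 4 is thus estimated at 46%, between 30% and 62%.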

Compound 4, percent growth inhibition at one concentration: 47.3%
Estimate against measurement, compound 4: 1.3 percentage points below; the measured number falls inside the stated range.
By their numbers in this assay, from the lowest: compounds 3, 2 and 4 (each within the scatter of the next); then compound 1.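

Methoxy and chloro differ in heavy atoms and hydrogen-bond acceptors, and no earlier pair tested an exchange at this position on the outer ring. In this assay, chloro in place of methoxy on the aromatic carbon para to a large group gives a number 1.6 percentage points higher from compound 3 to compound 4 (within the scatter) so in this pair the two groups cannot be told apart, and the hydrogen-bond acceptor that leaves with the methoxy is not needed to keep the number at the one concentration tested. Nothing on hand explains this result.

Still open, from the compounds shown here alone, is whether a quite different group at this position, such as an amine or a carboxylic acid, would also leave the number in place. The compounds shown also leave open whether this exchange would behave the same way on the core of compound 1.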